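The compounds below may be only part of what the source reports. "The series", "measured", "known", "first", "only" and "open" are said of these compounds alone.

Within the data shown here, in a functional assay on CCRF-CEM cells (Homo sapiens) for inhibition, read by MTT assay, with a stated time of 72 h (on this read-out lower numbers stand for stronger inhibition and higher numbers for weaker inhibition), three compounds have numbers so far. Compound 1 (`COc1cc(NC(=O)/C=C/c2cccc(OCc3ccccc3)c2)cc(OC)c1OC`) gives 17300 nM, compound 2 (`C=C(Br)C(=O)Nc1cccc(/C=C/C(=O)Nc2ccc(F)cc2)c1`) gives 16600 nM, and compound 3 (`C=C(Br)C(=O)Nc1cccc(/C=C/C(=O)Nc2ccc(F)c(F)c2)c1`) gives 13 nM, the lowest of the three. Compound 4 (`C=C(Br)C(=O)Nc1cccc(/C=C/C(=O)NCc2ccc(C)cc2)c1`) has not yet been measured. It carries 4-methylbenzyl in place of 3,4-difluorophenyl on an amide-type nitrogen.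

Among the measured compounds shown here, only one measured step bears on this change. It is a 1300-fold lower number from compound 2 to compound 3 (3.11 log units; beyond the scatter), produced by fluoro in place of hydrogen on an aromatic carbon. This step lies within the same group that compound 4 gives up, and it shows that a single replacement there can move the number by a very large amount. For the measured compounds named here, no measured compound has a benzyl group on that nitrogen, so the data offer no direct precedent for the incoming group. Going by the values given here, compound 4 also lacks the 3,4-difluorophenyl group of compound 3, and the low number is so far seen only with that group. A large move towards higher numbers is therefore expected, probably short of the full size of the measured step, with wide uncertainty. The expected change is a 69-fold higher number from compound 3 to compound 4 (1.84 log units; beyond the scatter). For compound 4 the estimated value is 900 nM, with an expected range from 50 nM to 16000 nM.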

Compound 4, half-maximal inhibitory concentration: 550 nM
Estimate against measurement, compound 4: 1.6-fold (0.21 log units) above; low and high end bracket the measured number.
By their numbers in this assay, from the lowest: compound 3; then compound 4; then compounds 2 and 1 (each within the scatter of the next).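

In this assay, the step of a 42-fold higher number from compound 3 to compound 4 (1.63 log units; beyond the scatter) shows that 4-methylbenzyl on the amide-type nitrogen does not keep the low number seen with 3,4-difluorophenyl, so among these compounds that number remains tied to the 3,4-difluorophenyl group. The step of a 30-fold lower number from compound 2 to compound 4 (1.48 log units; beyond the scatter) shows that this position does not simply divide into 3,4-difluorophenyl and much weaker groups: a group with no fluorine gives a number well clear of the one seen with 4-fluorophenyl, so fluorine on the incoming group is not needed for a sub-micromolar number. No measurement shown here accounts for the order of these three groups on that nitrogen.

The change from an aryl to a benzyl group also adds a methyl group, so these compounds cannot show which of the two differences matters, and a plain benzyl or a 3,4-difluorobenzyl group on that nitrogen would help to separate them. On these data alone, it also remains open whether the strong effect of 3,4-difluorophenyl extends to related groups such as 3,4-dichlorophenyl or 3-chloro-4-fluorophenyl.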